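Swapping the Cap of a Hydroxamic Acid Antiproliferative

A few compounds are considered here, and "the series" means these few. Any claim that something is new, unique, unknown or untested is made for them only; others in the source may bear on it.

Three compounds sharing a hydroxamic acid chain were tested in a functional assay on NFF cells (Homo sapiens) for antiproliferative activity; on this read-out lower numbers stand for stronger inhibition and higher numbers for weaker inhibition. Compound 1 `CN(C)c1ccc(C(=O)NC(CCCCCC(=O)NO)C(=O)NC2CCCc3ccccc32)cc1` gave 1810 nM, compound 2 `CC(C)CCNC(=O)C(CCCCCC(=O)NO)NC(=O)c1ccco1` gave 4400 nM, and compound 3 `O=C(CCCCC[C@H](NC(=O)c1cc2ccccc2[nH]1)C(=O)NCc1ccccc1)NO` gave 1260 nM. Compound 3 has the lowest of the three numbers; its gap to compound 1 lies within the scatter, while its gap to compound 2 lies beyond it. Compound 4 `O=C(CCCCC[C@H](NC(=O)c1ccc(C(F)(F)F)cc1)C(=O)NCc1ccccc1)NO` differs from compound 3 in one place: 4-(trifluoromethyl)phenyl in place of 1H-indol-2-yl on a carbonyl carbon. Within the data shown here, no step between measured compounds isolates such a swap, so the expectation rests on compound 3 alone. Compound 4 is expected to give 1900 nM, within 700 nM to 5000 nM. The step of a 1.5-fold higher number from compound 3 to compound 4 (0.18 log units; within the scatter) is expected to stay close to the scatter, tending toward a higher number.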

Compound 4, half-maximal inhibitory concentration: 1610 nM
Estimate against measurement, compound 4: 1.2-fold (0.07 log units) above, and the stated range covers the measured number.
By their numbers in this assay, from the lowest: compounds 3, 4 and 1 (each within the scatter of the next); then compound 2.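

In this assay the swap of 1H-indol-2-yl for 4-(trifluoromethyl)phenyl on the carbonyl carbon gives a 1.3-fold higher number from compound 3 to compound 4 (0.11 log units; within the scatter) and so stays within the scatter. This position therefore tolerates the loss of the five-membered aromatic ring and its hydrogen-bond donor, with no step beyond the scatter. No measurement offered here accounts for this result. The compounds shown leave open whether an amine or a carboxylic acid in place of trifluoromethyl would keep the number within the scatter of compound 3.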